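A few compounds are considered here, and "the series" means these few. Any claim that something is new, unique, unknown or untested is made for them only; others in the source may bear on it.

Of the compounds shown here, three sharing one core have been measured in a physicochemical assay for solubility, at pH 2; on this read-out higher numbers stand for higher solubility and lower numbers for lower solubility. In this assay, compound 1 `NC(=O)c1ccc(-c2cnc3ccc(-c4cccc(S(=O)(=O)C5CC5)c4)nn23)cc1` gives 6300 nM, the lower of the two numbers available, while compound 2 `C[S+]([O-])c1cccc(-c2ccc3ncc(-c4ccc(C(N)=O)cc4)n3n2)c1` gives 112000 nM. Compound 3 `CS(=O)(=O)c1ccc(-c2cnc3ccc(-c4cccc(C(=O)NCCO)c4)nn23)cc1` is reported only as a limit of the assay, > 200000 nM.

Compound 4 `C[S+]([O-])c1ccc(-c2cnc3ccc(-c4cccc(S(=O)(=O)C5CC5)c4)nn23)cc1` has not yet been measured. It departs from compound 1 by one change: a group of 3 heavy atoms (1 carbon, 1 oxygen, 1 sulfur; no ring) in place of a group of 3 heavy atoms (1 carbon, 1 nitrogen, 1 oxygen; no ring), on an aromatic carbon. In other words, a group of 3 heavy atoms (1 carbon, 1 oxygen, 1 sulfur; no ring) takes the place of carbamoyl on an aromatic carbon of a six-membered aromatic ring of carbon only, para to a large group.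

Among the measured compounds shown here, one measured step bears on this change, and it was large: an 18-fold higher number from compound 1 to compound 2 (1.25 log units; beyond the scatter). The same entering group appears in that step, but it replaces a different group there, and compound 2 keeps the carbamoyl that compound 4 loses. That step is therefore only a partial guide, so an upward step of smaller size is expected in this assay. The expected change is a 4.0-fold higher number from compound 1 to compound 4 (0.60 log units; beyond the scatter). For compound 4, the estimated value is 25000 nM, with an expected range of 7000 nM to 90000 nM.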

Compound 4, solubility: 61000 nM
For compound 4 the middle estimate is 2.4-fold (0.39 log units) below the measured one; low and high end bracket the measured number.
By their numbers in this assay, from the lowest: compound 1; then compounds 4 and 2 (each within the scatter of the next). At a limit, above all of these: compound 3.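

In this assay, carbamoyl proves not to be needed for a higher number at this position: a 9.7-fold higher number from compound 1 to compound 4 (0.99 log units; beyond the scatter), when the group of one carbon, one oxygen and one sulfur takes its place on an aromatic carbon of the six-membered aromatic ring of carbon only, para to a large group. The other step, an 18-fold higher number from compound 1 to compound 2 (1.25 log units; beyond the scatter), brought in the same group but kept carbamoyl and gave up the group of 6 heavy atoms with its three-membered ring, so this entering group now gives a higher number than compound 1 at two different places, and no compound shown goes against that. Nothing measured here tells why the number moves at either place.

Still open, on these data alone, is what other groups would give at this position, such as an amine, a carboxylic acid or a longer chain ending in a hydroxyl group. The compounds shown also leave open what happens when the entering group stands at both places in one molecule, with both carbamoyl and the group with the three-membered ring gone.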